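The source may report more compounds than this note shows. Statements on the series, on what has been measured and on what is new or still open speak of the compounds shown alone.

Measured so far in an ADME assay on microsomes from liver (Homo sapiens) for metabolic stability; a higher number here means faster removal of the compound, a lower number slower removal:
Compound 1 `Cc1ccc([C@H](C)NC(=O)Cn2nnc3ccccc3c2=O)c(C)c1` gives 33 mL/min/kg.
Compound 2 `COc1cc(C)ccc1[C@H](C)NC(=O)Cn1nnc2ccccc2c1=O` gives 30 mL/min/kg.
Compound 3 `COc1ccc2nnn(CC(=O)N[C@@H](C)c3ccc(C)cc3)c(=O)c2c1` gives 58 mL/min/kg.

Compound 3 and compound 2 are built from the same atoms joined differently; the difference between the two cores is not broken down here. Compound 3 and compound 1, and compound 3 and compound 2, give values that lie within the scatter of one another, so no order among the three is claimed.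

Compound 4 `Cc1ccc([C@H](C)NC(=O)Cn2nnc3ccc(C)cc3c2=O)cc1` has not yet been run in this assay. It differs from compound 3 in one place: methyl in place of methoxy on an aromatic carbon. The same kind of change has been measured once, from compound 2 to compound 1: methyl in place of methoxy on an aromatic carbon, and its step in this assay was a 1.1-fold higher number from compound 2 to compound 1 (0.04 log units; within the scatter). The surroundings are not identical: in the measured pair the group sits ortho to a large group and meta to a methyl group, whereas in compound 4 it sits on the fused ring, meta to a fused ring and para to a fused ring.

Resting on that single earlier step a 1.1-fold higher number from compound 2 to compound 1 (0.04 log units; within the scatter), the step from compound 3 to compound 4 is expected to be a 1.0-fold higher number from compound 3 to compound 4 (0.01 log units; within the scatter). Compound 4 is therefore estimated at 60 mL/min/kg in this assay, with a range from 30 mL/min/kg to 120 mL/min/kg.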

Compound 4, clearance: 179 mL/min/kg
Beside the measured number, compound 4's estimate is 3.0-fold (0.47 log units) below it, and the stated range ends below it.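

In this assay, putting methyl in place of methoxy on an aromatic carbon of the fused ring gives a 3.1-fold higher number from compound 3 to compound 4 (0.49 log units; beyond the scatter), so on this core the change does not leave the number where it stood. Going by these compounds alone, the change therefore cannot be carried from one core to the other at a fixed size, as the two measured steps show: the same change on two cores in this assay, a 1.1-fold higher number (0.04 log units; within the scatter) from compound 2 to compound 1 and a 3.1-fold higher number (0.49 log units; beyond the scatter) from compound 3 to compound 4, 2.8-fold (0.45 log units) apart, beyond the scatter of two such steps With only one step on each core, and with the two pairs differing both in the core and in where the group sits, these data do not show which of those differences sets the gap, nor which way or how far the change would move the number on a further core.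

Still open, going by these compounds, is how the number moves with other groups at this place on the core, such as a chlorine atom, an amine or a carboxylic acid. Also open, on these data alone, is whether the step from methoxy to methyl keeps its size when the group sits elsewhere on the fused ring.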